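This account rests on a few compounds, and the source may have more. Where it says the series, first, only, none or still open, it means among the compounds named here.

Among the compounds with values here, compound 2 `O=C(O)CCCC(=O)N1CCC(NS(=O)(=O)c2cc(S(=O)(=O)c3ccccc3)ccc2C(F)(F)F)CC1` gives 570 nM in an assay on U2OS cells for inhibition of secreted frizzled-related protein 1 (Homo sapiens), read by a luciferase reporter, with a stated time of 18 h (on this read-out higher numbers stand for an effect only at larger amounts of compound and lower numbers for an effect already at smaller amounts), the higher of the two numbers so far; compound 1 `O=C(O)c1cccc(S(=O)(=O)N2CCC(NS(=O)(=O)c3cc(S(=O)(=O)c4ccccc4)ccc3C(F)(F)F)CC2)c1` gives 190 nM. Within the data shown here, the only measured step, a 3.0-fold higher number from compound 1 to compound 2 (0.48 log units; beyond the scatter), swapped one group on the ring nitrogen for another and moved the number modestly upward. Compound 3 `CC(C)(O)CCN1CCC(NS(=O)(=O)c2cc(S(=O)(=O)c3ccccc3)ccc2C(F)(F)F)CC1` differs from compound 2 by 3-hydroxy-3-methylbutyl in place of (3-carboxypropyl)carbonyl on an amine nitrogen in a ring. Among the measured compounds shown here, no measured step involves a 3-hydroxy-3-methylbutyl group or the removal of a carbonyl, so the direction cannot be read from the data. Compound 3 is therefore expected near compound 2, at 600 nM (range 200 nM to 2000 nM), an expected step of a 1.1-fold higher number from compound 2 to compound 3 (0.02 log units; within the scatter).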

Compound 3, half-maximal effective concentration: 630 nM
The estimate for compound 3 lay 1.1-fold (0.02 log units) below the measured number; measured number inside the range.
By their numbers in this assay, from the lowest: compound 1; then compounds 2 and 3 (each within the scatter of the next).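

Exchanging (3-carboxypropyl)carbonyl for 3-hydroxy-3-methylbutyl on the ring nitrogen leaves the number within the scatter (a 1.1-fold higher number from compound 2 to compound 3 (0.04 log units; within the scatter)), so at this position, a chain with neither a carbonyl nor a carboxylic acid performs on a par with the chain that has both. Compound 1, with its (3-carboxyphenyl)sulfonyl group, now stays ahead of both chains (a 3.3-fold higher number from compound 1 to compound 3 (0.52 log units; beyond the scatter)). No supporting measurement explains these results. Going by these compounds, it remains open whether the sulfonyl or the aromatic ring of compound 1 accounts for its lower number. An amine or a longer chain at this nitrogen is also untested by the compounds shown here.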